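Extending a methyl on the piperazine ring to ethyl

The compounds below may be only part of what the source reports. "The series", "measured", "known", "first", "only" and "open" are said of these compounds alone.

Compound 1, whose structure is `Cn1ccnc1SCC(=O)Nc1ccc(-c2nc(-c3ccccc3)c(-c3ccccc3)n2C)cc1`, and compound 2, whose structure is `CN1CCN(CC(=O)Nc2ccc(-c3nc(-c4ccccc4)c(-c4ccccc4)n3C)cc2)CC1`, share a core and differ only in the group attached to the saturated chain carbon bound to the carbonyl carbon. In a functional assay on HT-29 cells (Homo sapiens) for cytotoxicity, read by MTT assay, with a stated time of 24 h, tested at 6.4 ug/mL (a lower number here means a weaker effect, a higher number a stronger effect of the compound at the concentration tested), compound 1 gives 30.7%, while compound 2 gives 28.8%. The step of a number 1.9 percentage points lower from compound 1 to compound 2 (within the scatter) shows that swapping these two groups made no difference beyond the scatter. Compound 2 thus holds the lower of the two numbers shown, though its gap to compound 1 lies within the scatter, so neither can be called the weaker.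

Compound 3, whose structure is `CCN1CCN(CC(=O)Nc2ccc(-c3nc(-c4ccccc4)c(-c4ccccc4)n3C)cc2)CC1`, follows from compound 2 by the change (methyl in place of hydrogen on a saturated chain carbon bound to an amine nitrogen in a ring). Going by the values given here, no measured step touches this particular change; the only step available, from compound 1 to compound 2, concerned a different part of the molecule and was within the scatter. With nothing pointing either way, compound 3 is expected to stay close to compound 2, with a step of about a number 0.2 percentage points higher from compound 2 to compound 3 (within the scatter). The estimate for compound 3 in this assay is therefore 29%, with a range from 18% to 41%.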

Compound 3, a percentage reported as activity, at one concentration (the size of the read-out at that concentration, not a potency): 17.2%
For compound 3 the middle estimate is 11.8 percentage points above the measured one, and the stated range ends above it.
By their numbers in this assay, from the lowest: compound 3; then compounds 2 and 1 (each within the scatter of the next).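

This position turns out to be sensitive to a small change: in this assay, replacing 4-methylpiperazin-1-yl with 4-ethylpiperazin-1-yl, which is methyl in place of hydrogen on a saturated chain carbon bound to an amine nitrogen in a ring, gives a number 11.6 percentage points lower from compound 2 to compound 3 (beyond the scatter), so the effect of the compound at the tested concentration is weaker. The earlier exchange of a whole group gave only a number 1.9 percentage points lower from compound 1 to compound 2 (within the scatter), yet the smaller methyl-to-ethyl change moves the number beyond the scatter, and the comparison with the (1-methyl-1H-imidazol-2-yl)sulfanyl group now also shows a real difference, with a number 13.5 percentage points lower from compound 1 to compound 3 (beyond the scatter). No measurement available here explains why the longer group on the piperazine lowers the number.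

The compounds shown leave open whether the number keeps falling with a longer chain such as propyl or butyl, or whether a branched isopropyl or a ring such as cyclopropyl behaves like ethyl. They also leave open what a piperazine carrying only hydrogen on that nitrogen would give, which would show whether methyl itself contributes to the effect in this assay.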